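One Stereocentre Inverted on the Strongest Compound

The source may report more compounds than this note shows. Statements on the series, on what has been measured and on what is new or still open speak of the compounds shown alone.

Compound 3 `C#CC[C@@H]1C[C@H](n2cccc2C(=O)C(F)(F)F)C(=O)O1` gives 33.7% in a functional assay on N2a cells (Mus musculus), with a stated time of 48 h, tested at 0.01 uM (a higher number here means a stronger effect of the compound at the concentration tested, a lower number a weaker effect), the highest of the three measured numbers: compound 1 `C#CC[C@H]1C[C@H](n2cccc2)C(=O)O1` gives 12.2%, beyond the scatter below it, and compound 2 `C#CC[C@H]1C[C@H](n2cccc2C(=O)CC)C(=O)O1` gives 4.63%, furthest below. Going by the values given here, the only recorded single-site step, a number 7.6 percentage points lower from compound 1 to compound 2 (within the scatter), concerns a substituent and not configuration, so it bears little on the present change. Compound 4 `C#CC[C@H]1C[C@H](n2cccc2C(=O)C(F)(F)F)C(=O)O1` differs from compound 3 thus: the two compounds have the same atoms and bonds and differ only in configuration as drawn: 1 of 2 stereo elements differ; a stereocentre at a saturated ring carbon is drawn R in compound 3 and S in compound 4. Among the compounds with values here, no measured pair changes configuration alone, so the size of such a step is unknown; compounds 1 and 2 do share the drawn configuration of compound 4 at that ring carbon. Compound 4 is therefore estimated at 15%, within 2% to 35%, an expected step of a number 18.7 percentage points lower from compound 3 to compound 4 (beyond the scatter).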

Compound 4, a percentage reported as activity, at one concentration (the size of the read-out at that concentration, not a potency): 7.76%
Compound 4: the middle estimate sits 7.2 percentage points above what was measured; low and high end bracket the measured number.
By their numbers in this assay, from the lowest: compounds 2, 4 and 1 (each within the scatter of the next); then compound 3.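

Configuration at this saturated ring carbon matters in this assay: a number 25.9 percentage points lower from compound 3 to compound 4 (beyond the scatter), whereas the earlier substituent step stayed within the scatter. The gap can be assigned to this stereocentre alone, because nothing else varies: the fact that compounds 3 and 4 differ only in the configuration as drawn. With the carbon drawn S, the substituent changes stay within the scatter: a number 4.4 percentage points lower from compound 1 to compound 4 (within the scatter), and a number 3.1 percentage points higher from compound 2 to compound 4 (within the scatter).

As far as these compounds go, whether the R configuration has the same effect with hydrogen or propanoyl in place of (trifluoromethyl)carbonyl remains open. So does the outcome with an amide or a nitrile at that aromatic carbon.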